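The source may report more compounds than this note shows. Statements on the series, on what has been measured and on what is new or still open speak of the compounds shown alone.

Measured in an ADME assay on HepG2 cells (Homo sapiens) for cytotoxicity, read by MTT assay, with a stated time of 24 h; a higher number here means that more compound is tolerated, a lower number that less compound is tolerated:
compound 1 `CC(C)=CCC1=C(OCc2cn(C3CCNCC3)nn2)C(=O)c2ccccc2C1=O` gives 570000 nM
compound 2 `CC(C)=CCC1=C(OCc2cn(-c3cccnc3)nn2)C(=O)c2ccccc2C1=O` gives 1030000 nM

Among the measured compounds shown here, compound 2 stands alongside compound 1 as the only two numbers so far, and the gap between them lies within the scatter, so neither is set apart. Compound 3 `CC(C)=CCC1=C(OCc2cn(-c3ccccc3)nn2)C(=O)c2ccccc2C1=O` differs from compound 2 by phenyl in place of pyridin-3-yl on an aromatic nitrogen. For the measured compounds named here, the one measured step that bears on this place is the exchange on the same aromatic nitrogen, a 1.8-fold higher number from compound 1 to compound 2 (0.26 log units; within the scatter), which did not move the number beyond the scatter. A phenyl in place of a pyridin-3-yl is therefore expected to leave this assay much as it is, an expected step of a 1.1-fold lower number from compound 2 to compound 3 (0.06 log units; within the scatter). Compound 3 is estimated at 900000 nM, within 400000 nM to 2000000 nM.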

Compound 3, half-maximal cytotoxic concentration: 100000 nM
For compound 3 the middle estimate is 9.0-fold (0.95 log units) above the measured one; measured number below the stated range.
By their numbers in this assay, from the lowest: compound 3; then compounds 1 and 2 (each within the scatter of the next).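

In this assay the group on this aromatic nitrogen proves able to shift the number beyond the scatter: phenyl in place of pyridin-3-yl, same in heavy-atom count, gives a large step (a 10-fold lower number from compound 2 to compound 3 (1.01 log units; beyond the scatter)), and phenyl in place of piperidin-4-yl gives a modest one (a 5.7-fold lower number from compound 1 to compound 3 (0.76 log units; beyond the scatter)). Compound 3, whose ring here is carbon only, stands apart from both compounds whose ring holds a nitrogen. No available evidence accounts for this difference. As far as these compounds go, it remains open whether a phenyl bearing an amine or a carboxylic acid, or a pyridin-4-yl, would follow compound 2 or compound 3.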